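Dropping One Fluorine from the Amide Aryl Group

This account rests on a few compounds, and the source may have more. Where it says the series, first, only, none or still open, it means among the compounds named here.

Three measured compounds share one core and differ only in the group attached to the carbonyl carbon. Compound 1 `O=C(C1CC1)N1CCCC1c1nc(-c2cccc(F)c2)no1` carries a cyclopropyl there, and in an in vitro functional assay on HEK293-A cells for positive allosteric modulation of metabotropic glutamate receptor 5 (Homo sapiens), read by fluorescence and calcium flux, with a stated time of 140 s (a higher number here means that more compound is needed for the effect, a lower number that less compound is needed), compound 1 gives 2900 nM. Compound 2 `O=C(C1CCCC1)N1CCCC1c1nc(-c2cccc(F)c2)no1` carries a cyclopentyl, and in this assay compound 2 gives 1000 nM, which is a 2.9-fold lower number from compound 1 to compound 2 (0.46 log units; beyond the scatter). Compound 3 `O=C(c1ccc(F)c(F)c1)N1CCCC1c1nc(-c2cccc(F)c2)no1` carries a 3,4-difluorophenyl, and in this assay compound 3 gives 3700 nM; this sits alongside compound 1, with a 1.3-fold higher number from compound 1 to compound 3 (0.11 log units; within the scatter), and clearly apart from compound 2, with a 3.7-fold higher number from compound 2 to compound 3 (0.57 log units; beyond the scatter). Compound 4 `O=C(c1cccc(F)c1)N1CCCC1c1nc(-c2cccc(F)c2)no1` keeps the aryl group but with hydrogen in place of fluoro on an aromatic carbon. For the measured compounds named here, no measured step alters a substituent on this ring; the two steps ending at compound 3 swap the whole group for a cycloalkyl, so they offer only a loose guide, and a small change is expected. The estimated step is a 1.2-fold lower number from compound 3 to compound 4 (0.09 log units; within the scatter). Compound 4 is therefore expected to give 3000 nM, with a range from 1200 nM to 9000 nM.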

Compound 4, half-maximal effective concentration: 2600 nM
The estimate for compound 4 lay 1.2-fold (0.06 log units) above the measured number, within the range that was stated.
By their numbers in this assay, from the lowest: compound 2; then compounds 4, 1 and 3 (each within the scatter of the next).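

Removing the fluoro that sits para to a large group gives a 1.4-fold lower number from compound 3 to compound 4 (0.15 log units; within the scatter) in this assay, so the one change shown on the aryl ring itself cannot be told apart from the scatter. For the compounds shown here, the 3-fluorophenyl group also stays within the scatter of the cyclopropyl group (a 1.1-fold lower number from compound 1 to compound 4 (0.05 log units; within the scatter)), whereas replacing the cyclopentyl group with it gives a step beyond the scatter (a 2.6-fold higher number from compound 2 to compound 4 (0.41 log units; beyond the scatter)), so compound 2 remains the one compound set apart. Nothing available here explains why these numbers fall as they do.

As far as these compounds go, whether a larger group at this same carbon, such as methoxy or an amine, would shift the number remains open. So does the contribution of the fluoro group that stays on this ring in compound 4.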